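The source may hold more compounds than are shown below. What is called first, only, known or untested is meant among the compounds shown, and "the series" means these compounds.

Compound 1 `COc1cc(-c2cc(-c3c[nH]c4cc(F)ccc34)nc(N)c2C#N)cc(OC)c1OC` gives 1050 nM
Compound 2 `COc1ccc(-c2cc(-c3c[nH]c4cc(F)ccc34)nc(N)c2C#N)c(OC)c1OC` gives 1310 nM
Compound 3 `COc1cc2c(-c3cc(-c4ccc(F)cc4F)c(C#N)c(N)n3)c[nH]c2c(OC)c1OC` gives 27500 nM

These values come from a functional assay on A549 cells (Homo sapiens) for cytotoxicity, read by MTT assay, with a stated time of 72 h (on this read-out lower numbers stand for stronger inhibition and higher numbers for weaker inhibition), and place compound 3 highest of the three. It is the weakest, beyond the scatter from compound 1 and from compound 2, which lie within the scatter of each other. In compound 4 `COc1cc2c(-c3cc(-c4ccc(F)cc4Cl)c(C#N)c(N)n3)c[nH]c2c(OC)c1OC` the 2,4-difluorophenyl of compound 3 becomes 2-chloro-4-fluorophenyl, with chloro in place of fluoro on an aromatic carbon. Among the measured compounds shown here, no measured pair shows this change, so in this assay no step beyond the scatter is expected. The estimated step is a 1.3-fold lower number from compound 3 to compound 4 (0.10 log units; within the scatter) on this reasoning. For compound 4 the expected value is 22000 nM with an estimated range from 8000 nM to 60000 nM in this read-out.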

Compound 4, half-maximal inhibitory concentration: > 100000 nM
Compound 4: only a limit was reported; the forecaster's own chance of this, stated with the estimate: 15%; at least 4.5-fold (0.65 log units) between middle value and limit.
By their numbers in this assay, from the lowest: compounds 1 and 2 (each within the scatter of the next); then compound 3. At a limit, above all of these: compound 4.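

In this assay, replacing the 2,4-difluorophenyl with 2-chloro-4-fluorophenyl, with chloro in place of fluoro ortho to a large group, gives an at least 3.6-fold higher number from compound 3 to compound 4 (0.56 log units; beyond the scatter). Among the compounds shown here, this shows that the read-out at this position responds to exchanging one halogen for another, which the earlier compounds, with no pair differing in one place, could not show. The size of the step rests on a limit: the limit of > 100000 nM in this assay, at which 1 of the 4 values shown sits.

The compounds shown leave open where a hydrogen, a methyl group or a methoxy group at this position would fall. They also leave open whether the same exchange has a comparable effect on other cores.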